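Amide side chain on the pyrrolidinyl series: compound 3 to compound 4

The source may report more compounds than this note shows. Statements on the series, on what has been measured and on what is new or still open speak of the compounds shown alone.

Measured in an ADME assay on L6 cells (Rattus norvegicus) for cytotoxicity, read by resazurin assay, with a stated time of 72 h; on this read-out lower numbers stand for stronger inhibition and higher numbers for weaker inhibition:
- compound 1 `CCN(CC)CC(=O)OC1CC2(N3CCCC3)CC(c3ccccc3)C1C(c1ccccc1)C2`: 49000 nM
- compound 2 `CN1CCN(CCC(=O)NC2CC3(N4CCCCC4)CC(c4ccccc4)C2C(c2ccccc2)C3)CC1`: 61100 nM
- compound 3 `O=C(CN1CCCCC1)OC1CC2(N3CCCC3)CC(c3ccccc3)C1C(c1ccccc1)C2`: 14200 nM

Compound 3, at 14200 nM, has the lowest of the three numbers, and compound 1 and compound 2 both stand above it beyond the scatter. The next compound is compound 4 `CN1CCN(CCC(=O)NC2CC3(N4CCCC4)CC(c4ccccc4)C2C(c2ccccc2)C3)CC1`, and the change is ((2-(4-methylpiperazin-1-yl)ethyl)carbonyl)amino in place of (((piperidin-1-yl)methyl)carbonyl)oxy on a saturated ring carbon. It takes place on a saturated ring carbon, while pyrrolidin-1-yl stays on the core.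

Among the measured compounds shown here, the only measured step is a 3.5-fold lower number from compound 1 to compound 3 (0.54 log units; beyond the scatter). It is modest and lies within the ester group that leaves here, so it shows that this group can move the number, but it does not size the present, larger exchange. For the measured compounds named here, no measured pair isolates that exchange.

The closest guide is compound 2, which carries the same ((2-(4-methylpiperazin-1-yl)ethyl)carbonyl)amino group, with piperidin-1-yl in place of pyrrolidin-1-yl, and reads 61100 nM. On that basis, a modest rise toward weaker inhibition is expected, of the order of a 3.2-fold higher number from compound 3 to compound 4 (0.50 log units; beyond the scatter).

For compound 4 the estimated value is 45000 nM, with an expected range of 18000 nM to 110000 nM.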

Compound 4, half-maximal inhibitory concentration: 86700 nM
Beside the measured number, compound 4's estimate is 1.9-fold (0.28 log units) below it, within the range that was stated.
By their numbers in this assay, from the lowest: compound 3; then compounds 1, 2 and 4 (each within the scatter of the next).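

In this assay, among the compounds shown here, exchanging the ester side chain on this saturated ring carbon gives a 6.1-fold higher number from compound 3 to compound 4 (0.79 log units; beyond the scatter) and is the first step sized between the (((piperidin-1-yl)methyl)carbonyl)oxy group and the ((2-(4-methylpiperazin-1-yl)ethyl)carbonyl)amino group. The same amide group set against the diethylamino ester gives a 1.8-fold higher number from compound 1 to compound 4 (0.25 log units; within the scatter) and remains within the scatter, so the size of the exchange at this position depends on which ester is the reference point. On the core, the amide pair gives a 1.4-fold higher number from compound 2 to compound 4 (0.15 log units; within the scatter) with pyrrolidin-1-yl in place of piperidin-1-yl, so with this side chain the two rings are not told apart by this read-out.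

No measured evidence accounts for any of these steps.

The exchange changes the link and the chain together, so (((piperidin-1-yl)methyl)carbonyl)amino on the same ring carbon would be needed to separate the amide link from the 4-methylpiperazine chain. Also open, from the compounds shown here alone, is how a free hydroxyl or a primary amine on this carbon would read, and whether the pyrrolidin-1-yl and piperidin-1-yl pair stays within the scatter on the ester side chains.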